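The source may report more compounds than this note shows. Statements on the series, on what has been measured and on what is new or still open speak of the compounds shown alone.

Compound 1 `O=C(O)c1ccc2cc(N3CCC4(C=C(c5c(-c6c(Cl)cccc6Cl)noc5C5CC5)C4)CC3)ccc2n1` – 0.983 h
Compound 2 `O=C(O)c1cc(F)c2nc(N3CCC4(C=C(c5c(-c6ccccc6OC(F)(F)F)noc5C5CC5)C4)CC3)sc2c1` – 1.62 h
Compound 3 `O=C(O)c1cc(C(F)(F)F)c2cc(N3CCC4(C=C(c5c(-c6c(Cl)cncc6Cl)noc5C5CC5)C4)CC3)ccc2n1` – > 2 h

These are half-lives from an ADME assay on microsomes from liver (Homo sapiens) for metabolic stability; on this read-out higher numbers stand for a longer-lived compound and lower numbers for a shorter-lived compound. Compound 2 gives 1.62 h and compound 1 gives 0.983 h; these two numbers lie within the usual scatter of each other, so the data do not separate them. Compound 3 is reported only as a limit of the assay, > 2 h, and not as a number.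

The next compound to be measured is compound 4 `O=C(O)c1cc(F)c2nc(N3CCC4(C=C(c5c(-c6c(Cl)cccc6Cl)noc5C5CC5)C4)CC3)sc2c1`. It keeps the core of compound 2 and changes one group: 2,6-dichlorophenyl in place of 2-(trifluoromethoxy)phenyl on an aromatic carbon. In words, 2,6-dichlorophenyl takes the place of 2-(trifluoromethoxy)phenyl on an aromatic carbon of a five-membered aromatic ring with 1 nitrogen and 1 oxygen. For the measured compounds named here, no pair of measured compounds shows this swap on its own, so the only guide is indirect. The entering group also stands on compound 1, on a different core, and compound 1 gives 0.983 h, within the scatter of compound 2. Only a small move is therefore expected, a 1.2-fold lower number from compound 2 to compound 4 (0.10 log units; within the scatter), slightly downward and not beyond the scatter. For compound 4 the expected half-life is 1.3 h, with an estimated range from 0.7 h to 2.2 h.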

Compound 4, half-life: 0.85 h
For compound 4 the middle estimate is 1.5-fold (0.18 log units) above the measured one; the range from low to high includes it.
By their numbers in this assay, from the lowest: compounds 4, 1 and 2 (each within the scatter of the next). At a limit, above all of these: compound 3.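

In this assay, for the compounds shown here, the first direct comparison of these two groups on one core gives a 1.9-fold lower number from compound 2 to compound 4 (0.28 log units; within the scatter), so the half-life does not tell 2-(trifluoromethoxy)phenyl and 2,6-dichlorophenyl apart at this position. Going by these compounds alone, until now this swap could be judged only indirectly, through compound 1, which carries the entering group on a different core; here the shared core is held fixed and only this one group differs. On this core, then, the aromatic carbon of the five-membered aromatic ring with 1 nitrogen and 1 oxygen holds either of these two substituted phenyl groups with no difference in half-life that stands clear of the usual scatter of repeated measurements.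

As far as these compounds go, whether a much smaller group at this position, such as a methyl group, or a group carrying an amine would shift the half-life beyond that scatter remains open, as does whether this swap would read the same on other cores. Compound 3 offers no number to compare, since it is reported only as a limit: the limit of > 2 h in this assay, at which 1 of the 4 values shown sits.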